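Working notes: isopropyl in place of butyl on a sulfur

A few compounds are considered here, and "the series" means these few. Any claim that something is new, unique, unknown or untested is made for them only; others in the source may bear on it.

Measured so far in a functional assay on MDA-MB-231 cells (Homo sapiens) for antiproliferative activity, read by MTT assay, with a stated time of 72 h; on this read-out lower numbers stand for stronger inhibition and higher numbers for weaker inhibition
- compound 1 `S=C(SSC1CCCCC1)N1CCCC1` gives 4700 nM
- compound 2 `CCCCSSC(=S)N(CC)CC` gives 7400 nM

Within the data shown here, compound 2 lies within the usual scatter of compound 1, so no order can be read between the only two numbers. Among the measured compounds shown here, compound 3 `CCN(CC)C(=S)SSC(C)C` is not yet measured and, compared with compound 2, carries isopropyl in place of butyl on a sulfur as its one change. For the measured compounds named here, no pair of measured compounds differs at this place alone, so the series holds no direct precedent. The expectation rests only on compound 1 at 4700 nM and compound 2 at 7400 nM as the two values available. In this assay no step beyond the scatter is expected. The estimated step of a 1.2-fold lower number from compound 2 to compound 3 (0.09 log units; within the scatter) stays within the scatter. Compound 3 is expected at 6000 nM (estimated range 2500 nM to 14000 nM).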

Compound 3, half-maximal inhibitory concentration: 960 nM
Compound 3: the middle estimate sits 6.3-fold (0.80 log units) above what was measured, outside the stated range (below it).
By their numbers in this assay, from the lowest: compound 3; then compounds 1 and 2 (each within the scatter of the next).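

In this assay, the group on a sulfur whose other neighbours are sulfur emerges as a place where the read-out can move: isopropyl in place of butyl gives a 7.7-fold lower number from compound 2 to compound 3 (0.89 log units; beyond the scatter) as a single-place change, which the earlier two compounds could not show. Neither group carries a ring, a hydrogen-bond donor or acceptor, or a net charge, so the exchange is confined to carbon count and branching. No available evidence bears on why the step arises.

On these data alone, whether the step follows the branching or the shorter chain stays open, and a propyl or tert-butyl group on this sulfur would separate the two readings. Also open, as far as these compounds go, is whether the same exchange would carry over to the core of compound 1.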